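A methoxy group enters a cytotoxicity series

The source may report more compounds than this note shows. Statements on the series, on what has been measured and on what is new or still open speak of the compounds shown alone.

Measured so far:
Compound 2 `COc1cccc(-n2cc(COc3c(/C=C\C(=O)O)ccc(OC)c3CC=C(C)C)nn2)c1` — in a functional assay on A549 cells (Homo sapiens) for cytotoxicity, read by MTT assay, with a stated time of 24 h (on this read-out higher numbers stand for weaker inhibition and lower numbers for stronger inhibition), compound 2 gives 42700 nM
Compound 3 `COc1ccc(/C=C\C(=O)O)c(OCc2cn(-c3ccccc3)nn2)c1CC=C(C)C` — in this assay compound 3 gives 40500 nM
Compound 1 `COc1ccc(/C=C\C(=O)O)c(OCc2cn(-c3ccc(NC(C)=O)cc3)nn2)c1CC=C(C)C` — in this assay compound 1 gives "not determined" (no result reported)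

For the measured compounds named here, only two numbers exist, and compound 3 and compound 2 sit within the scatter of each other: a 1.1-fold lower number from compound 2 to compound 3 (0.02 log units; within the scatter). Going by the values given here, that step, hydrogen in place of methoxy on an aromatic carbon, is the only measured step and it changed nothing beyond the noise.

Compound 4 `COc1ccc(-n2cc(COc3c(/C=C\C(=O)O)ccc(OC)c3CC=C(C)C)nn2)cc1` has not yet been measured. It differs from compound 3 by methoxy in place of hydrogen on an aromatic carbon, on an aromatic carbon of a six-membered aromatic ring of carbon only, para to a large group. A methoxy on the same ring, at another place, made no difference in going from compound 2 to compound 3, so the expectation for compound 4 is a step of about a 1.0-fold lower number from compound 3 to compound 4 (0.01 log units; within the scatter), no change beyond the scatter. Compound 4 is estimated at 40000 nM in this assay, in the range 20000 nM to 80000 nM.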

Compound 4, half-maximal inhibitory concentration: 10200 nM
For compound 4 the middle estimate is 3.9-fold (0.59 log units) above the measured one; measured number outside the range, below it.
By their numbers in this assay, from the lowest: compound 4; then compounds 3 and 2 (each within the scatter of the next).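

In this assay, for the compounds shown here, phenyl to 4-methoxyphenyl is the first measured change that goes beyond the scatter, with a 4.0-fold lower number from compound 3 to compound 4 (0.60 log units; beyond the scatter) as its result. The place of the methoxy matters as well: 4-methoxyphenyl in place of 3-methoxyphenyl gives a 4.2-fold lower number from compound 2 to compound 4 (0.62 log units; beyond the scatter) on the same read-out, whereas removing the methoxy from that other place gives only a 1.1-fold lower number from compound 2 to compound 3 (0.02 log units; within the scatter) and stays within the scatter. No measurement shown here explains why this place on the ring responds.

Going by these compounds, it remains open whether the gain is particular to methoxy, or whether an ethoxy group, a fluorine atom or an amine at the same place would give a similar number. In this assay compound 1 gives "not determined" (no result reported) and so adds nothing on this question.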